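The source may hold more compounds than are shown below. What is called first, only, known or untested is meant among the compounds shown, and "the series" means these compounds.

Working notes on the series. In a functional assay on CHO cells for antagonist activity at Orexin/Hypocretin receptor type 1 (Homo sapiens), read by FLIPR and calcium flux (a higher number here means a weaker inhibitor, a lower number a stronger inhibitor), compound 2 `CNC(=O)[C@@H](c1ccccc1)N1CCn2c(C3CC3)nc(Cl)c2[C@@H]1CCc1ccc(C(F)(F)F)cc1` gives 30 nM and compound 1 `CCc1nc(Cl)c2n1CCN([C@@H](C(=O)NC)c1ccccc1)[C@H]2CCc1ccc(C(F)(F)F)cc1F` gives 45 nM. Compound 3 `CNC(=O)[C@@H](c1ccccc1)N1CCn2c(C3CC3)nc(Cl)c2[C@@H]1CCc1ccc(C(F)(F)F)c(F)c1` gives 53 nM in this assay, the highest of the three numbers, yet its distances to compound 1 and to compound 2 both fall within the scatter, so no order can be read among the three. Among the measured compounds shown here, the only measured step that changes a fluorine on the aromatic ring, a 1.8-fold higher number from compound 2 to compound 3 (0.25 log units; within the scatter), also stays within the scatter. Compound 4 `CNC(=O)[C@@H](c1ccccc1)N1CCn2c(C3CC3)nc(Cl)c2[C@@H]1CCc1ccc(C(F)(F)F)cc1F` is still to be measured in this assay; it carries 2-fluoro-4-(trifluoromethyl)phenyl in place of 3-fluoro-4-(trifluoromethyl)phenyl on a saturated chain carbon, two bonds along the chain from a saturated ring carbon. For the measured compounds named here, no measured step moves a fluorine between two positions of this ring. Compound 1, which carries the same 2-fluoro-4-(trifluoromethyl)phenyl group on its own core, gives a number in the same range as compound 2 and compound 3. The change from compound 3 to compound 4 is therefore expected to give no step beyond the scatter, a 1.3-fold lower number from compound 3 to compound 4 (0.12 log units; within the scatter). Compound 4 is estimated at 40 nM, within 20 nM to 85 nM.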

Compound 4, half-maximal inhibitory concentration: 94 nM
For compound 4 the middle estimate is 2.4-fold (0.37 log units) below the measured one; the whole stated range lies below it.
By their numbers in this assay, from the lowest: compounds 2, 1, 3 and 4 (each within the scatter of the next, the first and the last beyond it).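

In this assay, 2-fluoro-4-(trifluoromethyl)phenyl in place of 3-fluoro-4-(trifluoromethyl)phenyl gives a 1.8-fold higher number from compound 3 to compound 4 (0.25 log units; within the scatter) and so does not separate the two fluorine placements on this ring. Even so, fluoro in place of hydrogen now has a readable effect on the number in one placement: the new compound gives a 3.1-fold higher number from compound 2 to compound 4 (0.50 log units; beyond the scatter) against the within-scatter a 1.8-fold higher number from compound 2 to compound 3 (0.25 log units; within the scatter) for the earlier fluoro step. With the 2-fluoro-4-(trifluoromethyl)phenyl group held constant, cyclopropyl in place of ethyl on an aromatic carbon gives a 2.1-fold higher number from compound 1 to compound 4 (0.32 log units; beyond the scatter) and is a modest step beyond the scatter.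

Still open, on these data alone, is how a chloro or methoxy group in place of this fluorine, or a pyridine ring in place of the phenyl ring, would read in this assay. No measurement shown here offers an explanation for these steps.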